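Acetylation across two naphthalene sulfonamide cores

A few compounds are considered here, and "the series" means these few. Any claim that something is new, unique, unknown or untested is made for them only; others in the source may bear on it.

Measured so far:
compound 1, `Cc1noc(NS(=O)(=O)c2cccc3ccc(N)cc23)c1C`, 1450 nM
compound 2, `CC(=O)Nc1ccc2cccc(S(=O)(=O)Nc3onc(C)c3C)c2c1`, 870 nM
compound 3, `Cc1noc(NS(=O)(=O)c2ccc3ccc(N)cc3c2)c1C`, 10000 nM

All numbers come from an assay on thoracic aorta for binding affinity to Endothelin-1 receptor (Rattus norvegicus); on this read-out lower numbers stand for stronger inhibition and higher numbers for weaker inhibition. Compound 1 and compound 3 are built from the same atoms joined differently; the difference between the two cores is not broken down here. In this assay compound 3 stands highest of the three, with compound 1 nearest and compound 2 furthest, both gaps beyond the scatter.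

Within the core of compound 1, the change acetyl in place of hydrogen on a nitrogen on an aromatic ring gave a 1.7-fold lower number from compound 1 to compound 2 (0.22 log units; within the scatter), a step inside the scatter.

Compound 4, `CC(=O)Nc1ccc2ccc(S(=O)(=O)Nc3onc(C)c3C)cc2c1`, has not been measured. It differs from compound 3 by acetyl in place of hydrogen on a nitrogen on an aromatic ring, the same change made at the same kind of place, on the core of compound 3. Among the compounds with values here, the expected step is a 1.7-fold lower number from compound 3 to compound 4 (0.22 log units; within the scatter), resting on the single earlier instance, a 1.7-fold lower number from compound 1 to compound 2 (0.22 log units; within the scatter), and no other pair shows this change. For compound 4 the estimate is 6000 nM, expected to fall between 2500 nM and 15000 nM.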

Compound 4, half-maximal inhibitory concentration: 42000 nM
The estimate for compound 4 lay 7.0-fold (0.85 log units) below the measured number; measured number outside the range, above it.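

In this assay, acetyl in place of hydrogen on a nitrogen on an aromatic ring gave a 4.2-fold higher number from compound 3 to compound 4 (0.62 log units; beyond the scatter), and this step does not match the one seen on the other core: the same change on two cores in this assay, a 1.7-fold lower number (0.22 log units; within the scatter) from compound 1 to compound 2 and a 4.2-fold higher number (0.62 log units; beyond the scatter) from compound 3 to compound 4, 7.0-fold (0.85 log units) apart, beyond the scatter of two such steps
The step measured on one core is therefore a poor guide to the step on the other in this series, and amino to acetamido cannot be treated as a change that carries over unaltered. The earlier step lies within the scatter, so the contrast is between no clear change on one core and a higher number on the other, not between two clear opposite effects, and with one pair per core the data give no reason for the difference.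

On these data alone, it remains open whether this dependence on the core is specific to acetyl or also appears with other groups on the same nitrogen, such as methyl, a longer acyl chain or benzoyl. Further pairs on both cores would show whether the step seen here on the core of compound 3 recurs.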